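The source may hold more compounds than are shown below. What is called first, only, known or untested is meant among the compounds shown, and "the series" means these compounds.

Compound 1 `COc1cc2c(cc1OC)CN(CCCCNC(=O)c1ccc(-c3cn(CCOCCF)nn3)cc1)CC2` gives 14700 nM in an assay on membranes from brain for displacement of a labelled ligand from Sigma non-opioid intracellular receptor 1 (Cavia porcellus), read by scintillation counting, with a stated time of 90 min; on this read-out higher numbers stand for weaker inhibition and lower numbers for stronger inhibition.
Compound 2 `COc1ccccc1Cn1cc(-c2ccc(C(=O)NCCCCN3CCc4cc(OC)c(OC)cc4C3)cc2)nn1` gives 8580 nM in this assay.
Compound 3 `COc1cc2c(cc1OC)CN(CCCCNC(=O)c1cc(-n3cc(CN(C)C)nn3)ccc1OC)CC2` gives 22400 nM in this assay.

Of these three numbers, compound 3 carries the highest; its gap to compound 1 is within the scatter, while its gap to compound 2 lies beyond it. Compound 4 `COc1cc2c(cc1OC)CN(CCCCNC(=O)c1cc(-n3cc(CN(C)C)nn3)ccc1OCCF)CC2` differs from compound 3 by fluoromethyl in place of hydrogen on a saturated chain carbon bound to an oxygen on an aromatic ring. Among the measured compounds shown here, only one measured step exists: a 1.7-fold lower number from compound 1 to compound 2 (0.23 log units; within the scatter). That change sits at another place and swaps other groups, so it bears on the present step only loosely, and it stayed within the scatter. For the measured compounds named here, no measured pair exchanges hydrogen for fluoromethyl at this place. Compound 4 is therefore expected to give 22000 nM in this assay, between 8000 nM and 60000 nM. The expected step is a 1.0-fold lower number from compound 3 to compound 4 (0.01 log units; within the scatter), which is estimated to stay within the scatter.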

Compound 4, inhibition constant: 21900 nM
Beside the measured number, compound 4's estimate is 1.0-fold (0.00 log units) above it; measured number inside the range.
By their numbers in this assay, from the lowest: compounds 2, 1, 4 and 3 (each within the scatter of the next, the first and the last beyond it).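

Going from methoxy to 2-fluoroethoxy in this assay gives a 1.0-fold lower number from compound 3 to compound 4 (0.01 log units; within the scatter). Among the compounds shown here, at this oxygen on an aromatic ring, then, adding fluoromethyl to compound 3 leaves the number unchanged within the scatter, and the earlier compounds included no comparison at this place. No measurement shown offers an explanation for this result.

Going by these compounds, it remains open whether an amine or a carboxylic acid at the end of this chain, or a much longer chain, would move the number. On these data alone, the same change on the core of compound 1 also remains untested here.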